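Swapping the Bicyclic Group on the Urea Nitrogen

The source may hold more compounds than are shown below. What is called first, only, known or untested is meant among the compounds shown, and "the series" means these compounds.

Of the compounds shown here, two with a shared core have been measured. Compound 1 `O=C(Nc1cncc2ccccc12)N1CCN(Cc2cccc(Oc3ccc(Cl)cc3)c2)CC1` carries one bicyclic aromatic group on the amide-type nitrogen, and compound 2 `O=C(Nc1noc2cccnc12)N1CCN(Cc2cccc(Oc3ccc(Cl)cc3)c2)CC1` carries another. In an assay on isolated protein for inhibition of Fatty-acid amide hydrolase 1 (Rattus norvegicus), with a stated time of 60 min (on this read-out lower numbers stand for stronger inhibition and higher numbers for weaker inhibition), compound 1 gives 8.3 nM. In this assay compound 2 gives 22 nM. The step of a 2.7-fold higher number from compound 1 to compound 2 (0.42 log units; beyond the scatter) shows that exchanging this group shifted the result by a modest amount. Going by the values given here, compound 2 therefore stands at the highest of the two numbers measured so far, with compound 1 as its only neighbour at a lower number.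

Compound 3 `O=C(Nc1cn2ccccc2n1)N1CCN(Cc2cccc(Oc3ccc(Cl)cc3)c2)CC1` has not yet been measured. It differs from compound 2 by a group of 9 heavy atoms (7 carbon, 2 nitrogen; one five-membered aromatic ring with 2 hetero atoms, one six-membered aromatic ring with 1 hetero atom) in place of a group of 9 heavy atoms (6 carbon, 2 nitrogen, 1 oxygen; one five-membered aromatic ring with 2 hetero atoms, one six-membered aromatic ring with 1 hetero atom), on an amide-type nitrogen. Among the compounds with values here, the only measured step that bears on such a swap at this position is a 2.7-fold higher number from compound 1 to compound 2 (0.42 log units; beyond the scatter), which was modest in size. A step of similar, modest size is expected in this assay for compound 3, but a single measured step does not tell the direction. Compound 3 is therefore expected to give 15 nM, within a range of 4 nM to 60 nM. This estimate means a step of a 1.5-fold lower number from compound 2 to compound 3 (0.17 log units; within the scatter).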

Compound 3, half-maximal inhibitory concentration: > 10000 nM
Compound 3: no number, only a limit (the forecaster's own chance of this, stated with the estimate: 2%); at least 660-fold (2.82 log units) between middle value and limit.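

Compound 3 gives no number in this assay, only a limit of the assay: the limit of > 10000 nM in this assay, at which 1 of the 3 values shown sits.

Even so, the steps can be read as large, with an at least 450-fold higher number from compound 2 to compound 3 (2.65 log units; beyond the scatter) and an at least 1200-fold higher number from compound 1 to compound 3 (3.08 log units; beyond the scatter), whereas the only earlier step at this position, a 2.7-fold higher number from compound 1 to compound 2 (0.42 log units; beyond the scatter), was modest. The new result therefore shows that the group on this amide-type nitrogen can decide whether any measurable inhibition remains, even though the groups of compound 2 and compound 3 have the same count of 9 heavy atoms and the same ring types, one five-membered aromatic ring with 2 hetero atoms and one six-membered aromatic ring with 1 hetero atom.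

What the three compounds leave open is which difference between these two groups matters, since the oxygen leaving, the change in hydrogen-bond acceptor count and the different arrangement of atoms within the rings all come together in this one swap. They also cannot tell whether a smaller group at the same place, such as a single pyridine ring, would keep a measurable number in this assay.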